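A Difluorophenyl Analog Judged Against Its Halogenated Relatives

This account rests on a few compounds, and the source may have more. Where it says the series, first, only, none or still open, it means among the compounds named here.

Three compounds built on the same core differ only in the aryl group attached to the aromatic nitrogen of the triazole. Compound 1 `COc1cc2c(Oc3ccc(NC(=O)c4cn(-c5ccccc5C)nn4)cc3F)ccnc2cc1OCCCN1CCCCC1` carries a 2-methylphenyl group, and in a functional assay on A549 cells (Homo sapiens) for cytotoxicity, read by MTT assay, with a stated time of 72 h (on this read-out higher numbers stand for weaker inhibition and lower numbers for stronger inhibition), compound 1 gives 3230 nM. Compound 2 `COc1cc2c(Oc3ccc(NC(=O)c4cn(-c5ccc(Br)cc5)nn4)cc3F)ccnc2cc1OCCCN1CCCCC1` carries a 4-bromophenyl group; in this assay compound 2 gives 230 nM. Compound 3 `COc1cc2c(Oc3ccc(NC(=O)c4cn(-c5c(Cl)cccc5Cl)nn4)cc3F)ccnc2cc1OCCCN1CCCCC1` carries a 2,6-dichlorophenyl group, and in this assay compound 3 gives 150 nM, the lowest of the three numbers, though the step of a 1.5-fold lower number from compound 2 to compound 3 (0.19 log units; within the scatter) is a small one, while the step of a 22-fold lower number from compound 1 to compound 3 (1.33 log units; beyond the scatter) is a large one.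

Compound 4 `COc1cc2c(Oc3ccc(NC(=O)c4cn(-c5ccc(F)c(F)c5)nn4)cc3F)ccnc2cc1OCCCN1CCCCC1` is the unmeasured relative. It differs from compound 3 by 3,4-difluorophenyl in place of 2,6-dichlorophenyl on an aromatic nitrogen. Among the measured compounds shown here, the steps that bear on this change are a 14-fold lower number from compound 1 to compound 2 (1.15 log units; beyond the scatter) and a 22-fold lower number from compound 1 to compound 3 (1.33 log units; beyond the scatter), which show that two different halogenated phenyl groups both gave far lower numbers than the methyl-bearing one, and a 1.5-fold lower number from compound 2 to compound 3 (0.19 log units; within the scatter), which shows that the two halogenated groups differed little from each other. Since compound 4 again carries a halogenated phenyl group, the expected step in this assay is a 2.0-fold higher number from compound 3 to compound 4 (0.30 log units; within the scatter), a modest upward movement at most. Compound 4 is therefore estimated at 300 nM in this assay, with a range from 100 nM to 1000 nM.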

Compound 4, half-maximal inhibitory concentration: 220 nM
Estimate against measurement, compound 4: 1.4-fold (0.13 log units) above; low and high end bracket the measured number.
By their numbers in this assay, from the lowest: compounds 3, 4 and 2 (each within the scatter of the next); then compound 1.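

In this assay the change to 3,4-difluorophenyl keeps the number within the scatter of both other halogenated compounds, with a 1.5-fold higher number from compound 3 to compound 4 (0.17 log units; within the scatter) and a 1.0-fold lower number from compound 2 to compound 4 (0.02 log units; within the scatter). The earlier compounds had shown this tolerance for only two halogenated phenyl groups, whereas compound 4 extends it to one that carries fluorine rather than chlorine or bromine, with its two halogens placed differently from those of compound 3, and a 15-fold lower number from compound 1 to compound 4 (1.17 log units; beyond the scatter) sets compound 1, the only one with no halogen on this phenyl group, apart from the other three. No measurement is at hand that would explain this grouping or the lack of separation among the halogenated compounds.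

The compounds shown leave open whether the halogens themselves matter or whether it is the methyl group of compound 1 that accounts for its separate place, since no phenyl group without any substituent appears among them. They also leave open how an amine, a carboxylic acid or a longer chain on this phenyl group would fare in this assay.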